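This account rests on a few compounds, and the source may have more. Where it says the series, first, only, none or still open, it means among the compounds named here.

Measured compounds:
compound 1, `CN(C(=O)c1ccccc1)c1ccc(C(O)(C(F)(F)F)C(F)(F)F)cc1`, which in an ADME assay on Li23 cells (Homo sapiens) for cytotoxicity, read by WST assay (on this read-out higher numbers stand for lower toxicity in this test and lower numbers for higher toxicity in this test), gives 65000 nM;
compound 2, `CCCCC(=O)N(C)c1ccc(C(O)(C(F)(F)F)C(F)(F)F)cc1`, which in this assay gives 26000 nM;
compound 3, `CN(c1ccc(C(O)(C(F)(F)F)C(F)(F)F)cc1)S(=O)(=O)c1ccccc1`, which in this assay gives 16000 nM.

Compound 3 gives the lowest of the three numbers: the step of a 4.1-fold lower number from compound 1 to compound 3 (0.61 log units; beyond the scatter) is beyond the scatter, whereas a 1.6-fold lower number from compound 2 to compound 3 (0.21 log units; within the scatter) is within it, so compound 2 and compound 3 cannot be told apart. Compound 4, `CN(c1ccc(C(O)(C(F)(F)F)C(F)(F)F)cc1)S(=O)(=O)c1ccccc1Cl`, differs from compound 3 by chloro in place of hydrogen on an aromatic carbon. For the measured compounds named here, none of the measured steps bears on this change: a 2.5-fold lower number from compound 1 to compound 2 (0.40 log units; beyond the scatter) and a 4.1-fold lower number from compound 1 to compound 3 (0.61 log units; beyond the scatter) alter the group on the nitrogen, not the phenyl of the phenylsulfonyl. With no guide in the data, no step beyond the scatter is expected, a 1.3-fold lower number from compound 3 to compound 4 (0.12 log units; within the scatter). Compound 4 is therefore estimated at 12000 nM, within a range from 5000 nM to 30000 nM.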

Compound 4, half-maximal cytotoxic concentration: 15000 nM
The estimate for compound 4 lay 1.3-fold (0.10 log units) below the measured number; measured number inside the range.
By their numbers in this assay, from the lowest: compounds 4, 3 and 2 (each within the scatter of the next); then compound 1.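

For the compounds shown here, the earlier compounds varied the group on the nitrogen, whereas this result is the first reading on the phenyl of the phenylsulfonyl group. In this assay, phenyl to 2-chlorophenyl, ortho to a large group, gives a 1.1-fold lower number from compound 3 to compound 4 (0.03 log units; within the scatter), so a single chloro at this place does not measurably shift the number. Nothing measured here explains this result. This single group cannot show how the place responds in general. From the compounds shown here alone, whether a methoxy group, an amine or a carboxylic acid here would give a step beyond the scatter remains open.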